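The compounds below may be only part of what the source reports. "The series", "measured", "known", "first", "only" and "open" are said of these compounds alone.

Measured compounds:
compound 1 `Cn1cc(-c2cnc3c(c2)c(-c2cccc(C#N)c2)cn3C)cn1` with 3000 nM
compound 2 `COc1cccc(-c2c[nH]c3ncc(-c4cnn(C)c4)cc23)c1` with 18000 nM
compound 3 `Cn1cc(-c2cnc3[nH]cc(-c4ccc(F)cc4)c3c2)cn1` with 9000 nM

In a physicochemical assay for solubility, read by LC-MS, in phosphate buffer, measured as thermodynamic solubility, with a stated time of 24 h, at pH 7.4 (on this read-out lower numbers stand for lower solubility and higher numbers for higher solubility), compound 2 gives the highest of the three numbers. Its nearest neighbour is compound 3, whose value sits within the scatter, so the two cannot be told apart; compound 1 lies clearly lower, beyond the scatter. Compound 4 `Cn1cc(-c2cnc3[nH]cc(-c4cccc([N+](=O)[O-])c4)c3c2)cn1` has not yet been measured in this assay. It shares the core of compound 2 and differs from it in one place: nitro in place of methoxy on an aromatic carbon, on an aromatic carbon of the six-membered ring of carbon only, meta to a large group. Among the compounds with values here, no measured pair in this set shows the effect of this exact exchange, so the expectation rests on the spread of the three known values alone. The step from compound 2 to compound 4 is expected to be a modest drop in solubility, a 3.0-fold lower number from compound 2 to compound 4 (0.48 log units; beyond the scatter), possibly reaching beyond the scatter. Compound 4 is therefore estimated at 6000 nM, with a range from 2000 nM to 18000 nM.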

Compound 4, solubility: 2000 nM
Beside the measured number, compound 4's estimate is 3.0-fold (0.48 log units) above it; the range from low to high includes it.
By their numbers in this assay, from the lowest: compounds 4 and 1 (each within the scatter of the next); then compounds 3 and 2 (each within the scatter of the next).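

In this assay, within the data shown here, the earlier compounds offered no pair differing in one place, so this is the first direct look at an exchange at this position. Nitro in place of methoxy, on an aromatic carbon meta to a large group, gives a 9.0-fold lower number from compound 2 to compound 4 (0.95 log units; beyond the scatter), which shows that the read-out is sensitive to what sits on this carbon. Neither group carries a net charge, so the step appears with no change in charge, and nothing measured here explains it.

Still open, as far as these compounds go, is how an amine, a hydroxyl or a carboxylic acid on this same carbon would read against methoxy and nitro. Also open, from the compounds shown here alone, is whether the same exchange on another carbon of this ring, or on a different core, would give a step of similar size.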